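From Pyrrolidin-1-yl to Chloro on the Shared Core

The compounds below may be only part of what the source reports. "The series", "measured", "known", "first", "only" and "open" are said of these compounds alone.

Of the compounds shown here, three have been measured in an ADME assay on microsomes from liver (Rattus norvegicus) for metabolic stability (a lower number here means slower removal, a higher number faster removal of the compound), and one has not. Compound 1 `CNc1nc(C#N)nc(NC2(C#N)CCCCC2)n1` gives 122 mL/min/kg in this assay. Compound 2 `CNc1nc(NC2(C#N)CCCCC2)nc(N(C)C)n1` gives 276 mL/min/kg. Compound 3 `CNc1nc(NC2(C#N)CCCCC2)nc(N2CCCC2)n1` is reported only as a limit of the assay, > 276 mL/min/kg, so its exact clearance is not known. That limit, (the limit of > 276 mL/min/kg in this assay, at which 1 of the 3 values shown sits), places compound 3 at the top of what this assay reports, above compound 1 and no lower than compound 2.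

The change to compound 4 `CNc1nc(Cl)nc(NC2(C#N)CCCCC2)n1` is chloro in place of pyrrolidin-1-yl on an aromatic carbon. Among the measured compounds shown here, two measured steps bear on it. an at least 2.2-fold higher number from compound 1 to compound 3 (0.35 log units; beyond the scatter) shows that bringing in pyrrolidin-1-yl in place of cyano raised clearance, and a 2.3-fold higher number from compound 1 to compound 2 (0.35 log units; beyond the scatter) shows a similar rise for dimethylamino. Between compound 2 and compound 3, a number no lower from compound 2 to compound 3 (the limit leaves the size open), the size cannot be read. Because the measured rise is tied to an at least 2.2-fold higher number from compound 1 to compound 3 (0.35 log units; beyond the scatter), removing pyrrolidin-1-yl is expected to undo much of it and bring clearance back toward the level of compound 1, though chloro itself has not been tested here. Compound 4 is therefore expected to give about 140 mL/min/kg, in the range 65 mL/min/kg to 276 mL/min/kg. The estimated step of an at least 1.9-fold lower number from compound 3 to compound 4 (0.29 log units; that floor lies within the scatter) is a modest drop.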

Compound 4, clearance: 867 mL/min/kg
Estimate against measurement, compound 4: 6.2-fold (0.79 log units) below; measured number above the stated range.
By their numbers in this assay, from the lowest: compound 1; then compound 2; then compound 4.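

Among the compounds shown here, at this place, between two ring nitrogen atoms, the choice of group counts for more than the earlier steps suggested: in this assay the change to chloro gives a 7.1-fold higher number from compound 1 to compound 4 (0.85 log units; beyond the scatter) and a 3.1-fold higher number from compound 2 to compound 4 (0.50 log units; beyond the scatter). A high number here therefore does not depend on an amine at this carbon, as chloro, a single chlorine atom with no hydrogen-bond acceptor, stands above the dimethylamino group of compound 2, while the cyano group of compound 1 stays lowest of the three compounds with readable numbers. Compound 3 is reported only as a limit, and its steps to compound 2 and compound 4 cannot be read because of that limit: the limit of > 276 mL/min/kg in this assay, at which 1 of the 4 values shown sits.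

The compounds shown leave open whether this rise belongs to chloro alone or would also appear with another halogen such as fluoro or bromo, or with a small group such as methoxy. They also leave open how the number in this assay would move with a carboxylic acid or a primary amine on this carbon, and whether pyrrolidin-1-yl lies above or below chloro.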